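This account rests on a few compounds, and the source may have more. Where it says the series, first, only, none or still open, it means among the compounds named here.

In a functional assay on MCF7 cells (Homo sapiens) for inhibition, read by MTT assay, with a stated time of 48 h (on this read-out lower numbers stand for stronger inhibition and higher numbers for weaker inhibition), compound 1 (`CCOC(=O)C1=C(N/C=N/c2cccnc2Cl)Nc2[nH]nc(C)c2C1c1ccc(N(C)C)cc1`) gives 4180 nM and compound 2 (`CCOC(=O)C1=C(N/C=N/c2ccccn2)Nc2[nH]nc(C)c2C1c1ccc(N(C)C)cc1`) gives 37300 nM, the higher of the two numbers. Compound 3 (`CCOC(=O)C(=NNC1=C(C(=O)OCC)C(c2ccc(N(C)C)cc2)c2c(C)n[nH]c2N1)C(=O)OCC`) differs from compound 2 on an amine nitrogen: a group of 12 heavy atoms (7 carbon, 1 nitrogen, 4 oxygen; no ring) in place of a group of 8 heavy atoms (6 carbon, 2 nitrogen; one six-membered aromatic ring with 1 hetero atom), on an amine nitrogen. Within the data shown here, the only measured step that bears on this change is an 8.9-fold higher number from compound 1 to compound 2 (0.95 log units; beyond the scatter), a modest one beyond the scatter, and it alters only the group that leaves here. A step of no greater size, towards a lower number, is therefore expected in this assay, estimated as a 3.1-fold lower number from compound 2 to compound 3 (0.49 log units; beyond the scatter). The estimate for compound 3 is 12000 nM, with an expected range of 2500 nM to 60000 nM.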

Compound 3, half-maximal inhibitory concentration: 89800 nM
Beside the measured number, compound 3's estimate is 7.5-fold (0.87 log units) below it; measured number above the stated range.
By their numbers in this assay, from the lowest: compound 1; then compound 2; then compound 3.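

In this assay, the open-chain group of 12 heavy atoms on the amine nitrogen gives a 2.4-fold higher number from compound 2 to compound 3 (0.38 log units; beyond the scatter) and a 21-fold higher number from compound 1 to compound 3 (1.33 log units; beyond the scatter), so the number rises against both ring-bearing groups. Among these three compounds, the order at this position runs from the chlorine-bearing ring of compound 1 through the ring of compound 2 to the open chain of compound 3. Nothing given here explains this order.

The change removes the ring and adds the ester groups together, so their separate contributions remain unresolved. From the compounds shown here alone, how a phenyl ring or a simple acetyl group would fall on this nitrogen also remains open.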